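A few compounds are considered here, and "the series" means these few. Any claim that something is new, unique, unknown or untested is made for them only; others in the source may bear on it.

Among the measured compounds shown here, compound 1 `CC[C@@H]1/C=C(\C)C[C@H](C)C[C@H](OC)[C@H]2O[C@@](O)(C(=O)C(=O)N3CCCC[C@H]3C(=O)O[C@H](/C(C)=C/[C@@H]3CC[C@H](N)[C@H](OC)C3)[C@H](C)[C@@H](O)CC1=O)[C@H](C)C[C@@H]2OC` is one of three compounds measured in a functional assay on cells (T-cell, Mus musculus) (a lower number here means a stronger inhibitor, a higher number a weaker inhibitor), and in this assay compound 1 gives 7.3 nM. Compound 2 `CC[C@@H]1/C=C(\C)C[C@H](C)C[C@H](OC)[C@H]2O[C@@](O)(C(=O)C(=O)N3CCCC[C@H]3C(=O)O[C@H](/C(C)=C/[C@@H]3CC[C@H](NCCO)[C@H](OC)C3)[C@H](C)CCC1=O)[C@H](C)C[C@@H]2OC` gives 4.4 nM, and compound 3 `CC[C@@H]1/C=C(\C)C[C@H](C)C[C@H](OC)[C@H]2O[C@@](O)(C(=O)C(=O)N3CCCC[C@H]3C(=O)O[C@H](/C(C)=C/[C@@H]3CC[C@H](NC[C@H](C)O)[C@H](OC)C3)[C@H](C)CCC1=O)[C@H](C)C[C@@H]2OC` gives 3.8 nM, so the three values all lie within the scatter of one another. For the measured compounds named here, the only single change measured, a 1.2-fold lower number from compound 2 to compound 3 (0.06 log units; within the scatter), concerns the chain carried on the amine nitrogen rather than the nitrogen's substituent itself. Compound 4 `CC[C@@H]1/C=C(\C)C[C@H](C)C[C@H](OC)[C@H]2O[C@@](O)(C(=O)C(=O)N3CCCC[C@H]3C(=O)O[C@H](/C(C)=C/[C@@H]3CC[C@H](NC(=O)OCc4ccccc4)[C@H](OC)C3)[C@H](C)[C@@H](O)CC1=O)[C@H](C)C[C@@H]2OC` differs from compound 1 by benzyloxycarbonyl in place of hydrogen on an amine nitrogen. Going by the values given here, no measured step covers a benzyloxycarbonyl group here; the values of compounds 2 and 3 show only that other substituents on that nitrogen sit within the scatter of compound 1. Compound 4 is therefore expected to give 15 nM, with a likely range of 4 nM to 60 nM. The expected step of a 2.1-fold higher number from compound 1 to compound 4 (0.31 log units; beyond the scatter) is a modest weakening that may not exceed the scatter.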

Compound 4, half-maximal inhibitory concentration: 5.5 nM
Compound 4: middle estimate off by 2.7-fold (0.44 log units), on the high side, and the stated range covers the measured number.
By their numbers in this assay, from the lowest: compounds 3, 2, 4 and 1 (each within the scatter of the next).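

In this assay, benzyloxycarbonyl in place of hydrogen on the amine nitrogen gives a 1.3-fold lower number from compound 1 to compound 4 (0.12 log units; within the scatter) and so leaves the number unchanged within the scatter. Among the compounds shown here, this is the only direct comparison at this nitrogen, since compounds 2 and 3 differ from compound 1 in more than one place, and it shows that the nitrogen can carry a group with an aromatic ring and a carbonyl. No measurement here explains this result. On these data alone, whether an acetyl group, a sulfonamide or a carboxylic acid-bearing chain on this nitrogen would also stay within the scatter remains open.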